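The source may report more compounds than this note shows. Statements on the series, on what has been measured and on what is new or still open speak of the compounds shown alone.

Compound 1 `CNCCNc1cc2c(cc1F)c(=O)c(C(=O)O)cn2Cc1ccc(-c2ccccc2)cc1` and compound 2 `CNCCCCNc1c(F)cc2c(=O)c(C(=O)O)cn(Cc3ccc(-c4ccccc4)cc3)c2c1OC` share a core and differ in the amine chain and a methoxy group. In an assay on isolated protein for inhibition of DNA topoisomerase 1 (Homo sapiens), with a stated time of 15 min (a lower number here means a stronger inhibitor, a higher number a weaker inhibitor), compound 1 reaches only the limit of the assay, > 200000 nM. In this assay compound 2 also reaches only the limit, > 200000 nM. Compound 2 thus stands at the limit, a position shared by the other value shown (the limit of > 200000 nM in this assay, at which 2 of the 2 values shown sit). Compound 3 `CNCCCCNc1cc2c(cc1F)c(=O)c(C(=O)O)cn2Cc1ccc(-c2ccccc2)cc1` differs from compound 2 by hydrogen in place of methoxy on an aromatic carbon. No step beyond the scatter is expected here. Compound 3 is expected to stay at the limit, estimated at 300000 nM within 100000 nM to 1000000 nM. The expected step is a step that the limit leaves unreadable from compound 2 to compound 3.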

Compound 3, half-maximal inhibitory concentration: 88300 nM
For compound 3 the middle estimate is 3.4-fold (0.53 log units) above the measured one, and the stated range ends above it.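

Hydrogen in place of methoxy on the aromatic carbon ortho to the (4-(methylamino)butyl)amino group brings an at least 2.2-fold lower number from compound 2 to compound 3 (0.35 log units; beyond the scatter) in this assay, so this position affects the result. The longer chain also counts: 2-(methylamino)ethyl in place of methylamino brings an at least 2.2-fold lower number from compound 1 to compound 3 (0.35 log units; beyond the scatter). Both sizes are only minimum sizes, because compound 1 and compound 2 sit at a limit of the assay: the limit of > 200000 nM in this assay, at which 2 of the 3 values shown sit.

As far as these compounds go, the full size of each step stays open. So does whether ethoxy or hydroxy on that aromatic carbon, or a longer amine chain, would shift the number further.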